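The compounds below may be only part of what the source reports. "The series", "measured", "known", "first", "only" and "open" are said of these compounds alone.

Within the data shown here, in a functional assay on RPTEC cells (Homo sapiens) for antiproliferative activity (on this read-out lower numbers stand for stronger inhibition of growth and higher numbers for weaker inhibition of growth), compound 1 `c1ccc(-c2cc(-c3cccnc3)nc(-c3ccccn3)c2)cc1` gives 0.36 ug/mL, at the upper end of the three numbers so far. Compound 2 `c1ccc(-c2cc(-c3ccsc3)cc(-c3cccnc3)n2)nc1` gives 0.31 ug/mL, within the scatter of compound 1, while compound 3 `c1ccc(-c2cc(-c3ccco3)cc(-c3ccccn3)n2)nc1` gives 0.0041 ug/mL, well under both. The next compound to read is compound 4 `c1ccc(-c2cc(-c3cccs3)cc(-c3cccnc3)n2)nc1`, and its change from compound 1 is thiophen-2-yl in place of phenyl on an aromatic carbon, opposite the ring nitrogen. Among the measured compounds shown here, the one measured step that bears on it is a 1.2-fold lower number from compound 1 to compound 2 (0.06 log units; within the scatter), with thiophen-3-yl in place of phenyl on an aromatic carbon. Compound 3 differs from compound 1 in more than one place, so its number cannot be tied to a single change, but it keeps the lower end of the range open. No shift beyond the scatter is therefore expected in this assay. The expected step is a 1.3-fold lower number from compound 1 to compound 4 (0.11 log units; within the scatter), within the scatter. For compound 4 the estimated value is 0.28 ug/mL, with an expected range of 0.08 ug/mL to 0.8 ug/mL.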

Compound 4, concentration for 50% growth inhibition: 0.056 ug/mL
Compound 4: the middle estimate sits 5.0-fold (0.70 log units) above what was measured; the measured number lies below the stated range.
By their numbers in this assay, from the lowest: compound 3; then compound 4; then compounds 2 and 1 (each within the scatter of the next).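

In this assay, this position, opposite the ring nitrogen, responds to a five-membered sulfur ring only with the right point of attachment: thiophen-2-yl gives a 6.4-fold lower number from compound 1 to compound 4 (0.81 log units; beyond the scatter), whereas thiophen-3-yl gave a 1.2-fold lower number from compound 1 to compound 2 (0.06 log units; within the scatter). The direct comparison of the two isomeric groups gives a 5.5-fold lower number from compound 2 to compound 4 (0.74 log units; beyond the scatter), so the earlier phenyl to thiophen-3-yl step did not show how far this position can move the number. No measurement shown explains the difference between the two attachments.

The compounds shown leave open whether an aromatic ring is needed here at all, which a saturated alkyl chain or an amine at this position would test. They also leave open whether a carboxylic acid or a methyl group on the thiophen-2-yl ring would keep the lower number of compound 4.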